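The source may report more compounds than this note shows. Statements on the series, on what has been measured and on what is new or still open speak of the compounds shown alone.

Going by the values given here, compound 2 `CCCc1nc(-c2ccccc2)c(CNCCN2CCN(c3cccc(C(F)(F)F)c3)CC2)o1` gives 1940 nM in an assay on HEK293 cells for inhibition of Voltage-dependent T-type calcium channel subunit alpha-1G (Homo sapiens), read by patch clamp (on this read-out lower numbers stand for stronger inhibition and higher numbers for weaker inhibition), one of only two numbers recorded so far; compound 1 `CCCc1nc(-c2ccccc2)c(CNCCN2CCN(c3cccc(C)c3C)CC2)o1` gives 1710 nM in this assay, which lies within the scatter of that result. Compound 3 `CCCc1nc(-c2ccccc2)c(CNCCN2CCN(c3ccccc3C)CC2)o1` differs from compound 2 in one place: 2-methylphenyl in place of 3-(trifluoromethyl)phenyl on an amine nitrogen in a ring. Among the compounds with values here, the single step that bears on this change is the earlier swap of the aryl group on the same ring nitrogen, a 1.1-fold higher number from compound 1 to compound 2 (0.05 log units; within the scatter), which stayed within the scatter. A further aryl exchange at this place is therefore expected to shift this assay only a little, a 1.1-fold lower number from compound 2 to compound 3 (0.03 log units; within the scatter). Compound 3 is estimated at 1800 nM, with a likely range from 700 nM to 4500 nM.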

Compound 3, half-maximal inhibitory concentration: 4300 nM
Compound 3: middle estimate off by 2.4-fold (0.38 log units), on the low side, within the range that was stated.
By their numbers in this assay, from the lowest: compounds 1 and 2 (each within the scatter of the next); then compound 3.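

In this assay the aryl group on this ring nitrogen does matter, since the exchange gives a 2.2-fold higher number from compound 2 to compound 3 (0.35 log units; beyond the scatter) and so moves beyond the scatter, which the earlier swap did not. Taking one methyl away from 2,3-dimethylphenyl gives a 2.5-fold higher number from compound 1 to compound 3 (0.40 log units; beyond the scatter) and shows that 2-methylphenyl stands apart from both earlier groups, which lie within the scatter of each other. Going by these compounds, whether a chlorine or a methoxy group on this phenyl ring would bring the number down remains open. Nothing at hand explains these shifts.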